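The compounds below may be only part of what the source reports. "The series", "measured", "known", "first", "only" and "open" are said of these compounds alone.

Two compounds share one core. Compound 1 `CC(C)(C)OC(=O)N1CCC(CCOC(=O)N2CCc3cc(S(C)(=O)=O)ccc32)CC1` in a functional assay on CHO cells for agonist activity at Glucose-dependent insulinotropic receptor (Homo sapiens), read by a luciferase reporter and cAMP accumulation, with a stated time of 2 h (on this read-out higher numbers stand for an effect only at larger amounts of compound and lower numbers for an effect already at smaller amounts), gives 68 nM. Compound 2 `CC(C)(C)OC(=O)N1CCC(CCOC(=O)N2CCc3cc(S(C)(=O)=O)cc(Cl)c32)CC1` in this assay gives 21 nM, the lowest of the two numbers, and the step of a 3.2-fold lower number from compound 1 to compound 2 (0.51 log units; beyond the scatter) sets the gap. Compound 3 `COc1cc(S(C)(=O)=O)cc2c1N(C(=O)OCCC1CCN(C(=O)OC(C)(C)C)CC1)CC2` differs from compound 2 by methoxy in place of chloro on an aromatic carbon. For the measured compounds named here, no measured step exchanges these two groups; the one step that bears on it is a 3.2-fold lower number from compound 1 to compound 2 (0.51 log units; beyond the scatter), where chloro entering lowered the number. Since compound 2 gives 21 nM, compound 3 is expected close to it, with a step of a 1.7-fold higher number from compound 2 to compound 3 (0.22 log units; within the scatter) estimated. The estimate for compound 3 is 35 nM, expected within 10 nM to 120 nM.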

Compound 3, half-maximal effective concentration in the Glucose-dependent insulinotropic receptor assay: 1700 nM
Estimate against measurement, compound 3: 49-fold (1.69 log units) below; the measured number lies above the stated range.
By their numbers in the Glucose-dependent insulinotropic receptor assay, from the lowest: compound 2; then compound 1; then compound 3.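

Swapping chloro for methoxy here is no small exchange: in the Glucose-dependent insulinotropic receptor assay it gives an 81-fold higher number from compound 2 to compound 3 (1.91 log units; beyond the scatter). Methoxy also compares poorly with plain hydrogen, with a 25-fold higher number from compound 1 to compound 3 (1.40 log units; beyond the scatter), so a group entering at this position can lower the number or raise it, depending on the group. The swap also makes the compound less lipophilic in a physicochemical assay for lipophilicity, read by HPLC, measured as octanol-water partition, at pH 7.4; a higher number here means a more lipophilic compound, a lower number a more polar compound: the measured distribution coefficient of compound 2, 3.2, and of compound 3, 2.8, a number 0.40 log units lower (beyond the scatter) In the physicochemical assay compound 2 gives 3.2 and compound 3 gives 2.8.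

Whether this modest shift accounts for the large step in the Glucose-dependent insulinotropic receptor assay stays open, as only hydrogen, chloro and methoxy are shown at this position. A methyl or a fluoro group on this carbon would add the next comparisons.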